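Open-chain sulfoxide replacing the sultam ring, compound 3

The source may hold more compounds than are shown below. What is called first, only, known or untested is meant among the compounds shown, and "the series" means these compounds.

Compound 2 `CC(C)c1noc(N2CCC(Oc3cc(N4CCc5cc(N6CCCS6(=O)=O)ccc54)ncn3)CC2)n1` holds the lowest of the two numbers in an assay on CHO cells for agonist activity at Glucose-dependent insulinotropic receptor (Homo sapiens), read by a luciferase reporter and cAMP accumulation, with a stated time of 2 h (on this read-out higher numbers stand for an effect only at larger amounts of compound and lower numbers for an effect already at smaller amounts), where compound 2 gives 9.7 nM. Its nearest neighbour is compound 1 `CC(C)c1noc(N2CCC(Oc3cc(N4CCc5cc(N6CCCCC6=O)ccc54)ncn3)CC2)n1`, which in this assay gives 17 nM; the step of a 1.8-fold lower number from compound 1 to compound 2 (0.24 log units; within the scatter) exchanged one ring for another at the same aromatic carbon and stayed within the scatter. Compound 3 `CC(C)c1noc(N2CCC(Oc3cc(N4CCc5cc([S+]([O-])CCO)ccc54)ncn3)CC2)n1` differs from compound 2 by a group of 5 heavy atoms (2 carbon, 2 oxygen, 1 sulfur; no ring) in place of a group of 7 heavy atoms (3 carbon, 1 nitrogen, 2 oxygen, 1 sulfur; one five-membered non-aromatic ring with 2 hetero atoms), on an aromatic carbon. Among the compounds with values here, no measured step opens the ring or brings a hydrogen-bond donor to this position, so the change to compound 3 is not directly covered; the one step that is known at this carbon was small. Hence no shift beyond the scatter is expected for compound 3, with a widened range for the untested change. Compound 3 is expected to give 20 nM in this assay, between 6 nM and 65 nM. The expected step is thus a 2.1-fold higher number from compound 2 to compound 3 (0.31 log units; beyond the scatter).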

Compound 3, half-maximal effective concentration: 48 nM
Estimate against measurement, compound 3: 2.4-fold (0.38 log units) below; low and high end bracket the measured number.
By their numbers in this assay, from the lowest: compounds 2 and 1 (each within the scatter of the next); then compound 3.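

In this assay, within the data shown here, the ring-bearing groups on this aromatic carbon tolerated exchange, but the open-chain sulfoxide is the first change here to go beyond the scatter (a 4.9-fold higher number from compound 2 to compound 3 (0.69 log units; beyond the scatter)), and the same holds against the six-membered lactam ring of compound 1 (a 2.8-fold higher number from compound 1 to compound 3 (0.45 log units; beyond the scatter)). Among these compounds, compound 3 thus has the highest number of the three, with both steps rated modest, and its single change removes the ring and brings in a hydrogen-bond donor together, so the two cannot be told apart. No measurement available here explains the shift.

An open-chain sulfone or a simple alkyl sulfoxide without the hydroxyl would separate the loss of the ring from the gain of the donor. From the compounds shown here alone, how an amine or a carboxylic acid on this carbon would read remains open.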